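The compounds below may be only part of what the source reports. "The series", "measured", "known", "first", "only" and "open" are said of these compounds alone.

Measured so far in a functional assay on cardiac atrium for antagonist activity at histamine H2 receptor (Cavia porcellus); a lower number here means a less potent compound, a higher number a more potent compound, by a factor of ten per unit of this negative logarithm:
- compound 1 `N#CN/C(=N\CCNc1ccc(N=[N+]=[N-])cc1[N+](=O)[O-])NCCCOc1cccc(CN2CCCCC2)c1`: 7.39
- compound 2 `N#CN/C(=N\CCNC(=O)c1ccncc1)NCCCOc1cccc(CN2CCCCC2)c1`: 6.89
- compound 3 `N#CN/C(=N\CCNC(=O)c1ccccc1)NCCCCOc1cccc(CN2CCCCC2)c1`: 7.67

Compound 2 gives the lowest of the three numbers; compound 1 stands higher and compound 3 higher still, both gaps beyond the scatter. Within the data shown here, the one measured step ending at compound 2 is a number 0.50 log units lower from compound 1 to compound 2 (beyond the scatter).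

Compound 4 `N#CN/C(=N\CCCCCNC(=O)c1ccccc1)NCCCOc1cccc(CN2CCCCC2)c1` differs from compound 2 by 3-benzamidopropyl in place of ((pyridin-4-yl)carbonyl)amino on a saturated chain carbon, two bonds along the chain from a double-bonded nitrogen. Among the measured compounds shown here, no measured step covers this change directly. Compound 3 carries a benzamide on a different chain and gives 7.67, which only shows that a benzamide can sit in this series with a higher number than compound 2. For compound 4 a modest rise is expected, a number 0.41 log units higher from compound 2 to compound 4 (beyond the scatter), with wide uncertainty, so compound 4 is estimated at 7.3, range 6.6 to 8.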

Compound 4, negative logarithm of the antagonist equilibrium constant: 6.58
Beside the measured number, compound 4's estimate is 0.72 log units above it; the whole stated range lies above it.
By their numbers in this assay, from the lowest: compound 4; then compound 2; then compounds 1 and 3 (each within the scatter of the next).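

In this assay the exchange gives a number 0.31 log units lower from compound 2 to compound 4 (beyond the scatter), so 3-benzamidopropyl at this saturated chain carbon does not raise the number over ((pyridin-4-yl)carbonyl)amino. The change swaps the ring and lengthens the chain together, and the compounds shown do not separate those two parts. Nothing available accounts for the lower number.

Open, from the compounds shown here alone, is whether a pyridine ring on the longer chain would read differently from the benzamide. Also open, going by these compounds, is how a primary amine or a carboxylic acid would read at the chain end.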